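A few compounds are considered here, and "the series" means these few. Any claim that something is new, unique, unknown or untested is made for them only; others in the source may bear on it.

Measured in an assay on HEK293 cells for displacement of a labelled ligand from D(4) dopamine receptor (Homo sapiens), read by scintillation counting, with a stated time of 60 min; a lower number here means a stronger inhibitor, a higher number a weaker inhibitor:
compound 1 `Cc1cccc(NC(=O)CN2CCN(c3ccc(Cl)cn3)CC2)c1` gives 95 nM
compound 2 `Cc1ccc(C2CCN(CC(=O)Nc3cccc(C)c3)CC2)nc1` gives 41.7 nM
compound 3 `Cc1cccc(NC(=O)CN2CCC(c3ccccc3)CC2)c1` gives 25.8 nM

Compound 1 has the highest number of the three, and its gap to compound 2 as well as to compound 3 lies beyond the scatter. Going by the values given here, the only single-point step among the measured compounds, a 1.6-fold lower number from compound 2 to compound 3 (0.21 log units; within the scatter), concerns the group on a saturated ring carbon and falls within the scatter. Compound 4 `O=C(CN1CCN(c2ccc(Cl)cn2)CC1)Nc1cccnc1` differs from compound 1 on the amide-type nitrogen: pyridin-3-yl in place of 3-methylphenyl on an amide-type nitrogen. Among the compounds with values here, no measured step touches this position, so nothing in the set speaks for or against a change in this assay, and the estimate stays near compound 1 with a wide range. Compound 4 is expected to give 150 nM (45 nM to 500 nM), the step of a 1.6-fold higher number from compound 1 to compound 4 (0.20 log units; within the scatter) being expected to remain within the scatter.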

Compound 4, inhibition constant: 5000 nM
Estimate against measurement, compound 4: 33-fold (1.52 log units) below; measured number above the stated range.
By their numbers in this assay, from the lowest: compounds 3 and 2 (each within the scatter of the next); then compound 1; then compound 4.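

Going by these compounds alone, the amide-type nitrogen proves a sensitive position in this assay: pyridin-3-yl in place of 3-methylphenyl gives a 53-fold higher number from compound 1 to compound 4 (1.72 log units; beyond the scatter), whereas the only earlier step, on a saturated ring carbon, stayed within the scatter. The change removes the methyl group and brings in a ring nitrogen at once, and this single step cannot separate the two. Nothing at hand explains the size of this loss.

Open, on these data alone, is which of the two changes carries the loss; a 5-methylpyridin-3-yl group on the amide-type nitrogen would keep the methyl with the ring nitrogen. Also open, as far as these compounds go, is whether the same change acts alike on the core of compound 3.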